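The compounds below may be only part of what the source reports. "The series", "measured", "known", "first", "only" and "open" are said of these compounds alone.

Compound 1 `Cc1ccnc(/C(N)=N/NC(=S)N2CCCCCC2)c1` gives 70% in a functional assay on A-375 cells (Homo sapiens) for cytotoxicity, read by MTT assay, with a stated time of 72 h, tested at 3 uM; a higher number here means more inhibition of growth at the concentration tested, a lower number less inhibition of growth. Compound 2 `Cc1ccnc(/C(N)=N/NC(=S)N2CCCCC2)c1` gives 69.5% in this assay.

Compound 1 and compound 2 lie within the scatter of each other in this assay, so the two numbers cannot be told apart. The next compound, compound 3 `N/C(=N\NC(=S)N1CCCCCC1)c1ccccn1`, is not yet measured. It differs from compound 1 in one place: hydrogen in place of methyl on an aromatic carbon. Among the compounds with values here, no step of this kind is known here, so the size of the change in this assay is expected to be small, with no clear direction beyond the scatter. The expected step of a number 5 percentage points lower from compound 1 to compound 3 (within the scatter) is modest. Compound 3 is estimated at 65%, within a range from 45% to 80%.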

Compound 3, percent growth inhibition at one concentration: 78.6%
Compound 3: the middle estimate sits 13.6 percentage points below what was measured, within the range that was stated.
By their numbers in this assay, from the lowest: compounds 2, 1 and 3 (each within the scatter of the next).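

In this assay hydrogen in place of methyl on the aromatic carbon opposite the ring nitrogen gives a number 8.6 percentage points higher from compound 1 to compound 3 (within the scatter) and so leaves the number within the usual scatter. Compounds 1 and 2 both carried the methyl, so only compound 3 shows that growth inhibition at this level does not depend on that group. Nothing measured here accounts for this step. 

From the compounds shown here alone, whether a methoxy group, an amine or a chlorine atom at this position would keep the number at this level remains open. So does whether the same change on compound 2 would give a similar step.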